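Para-alkyl growth on the benzylic aryl in an alpha-1 series

The source may hold more compounds than are shown below. What is called first, only, known or untested is meant among the compounds shown, and "the series" means these compounds.

Measured compounds:
compound 1 `COc1ccccc1N1CCN(CCC(Oc2ccc(C(=O)Nc3ccccc3OCCCC(=O)O)cc2)c2ccc(C)cc2)CC1` — 15.9 nM
compound 2 `CCc1ccc(C(CCN2CCN(c3ccccc3OC)CC2)Oc2ccc(C(=O)Nc3ccccc3OCCCC(=O)O)cc2)cc1` — 39.8 nM

In an assay on Prostate gland (Oryctolagus cuniculus) for inhibition of Adrenergic receptor alpha-1 (Homo sapiens) (on this read-out lower numbers stand for tighter binding and higher numbers for weaker binding), compound 1 gives 15.9 nM and compound 2 gives 39.8 nM. Within the data shown here, the only step between them is a 2.5-fold higher number from compound 1 to compound 2 (0.40 log units; beyond the scatter), so compound 2 holds the highest number of the two and the gap to compound 1 is beyond the scatter.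

Compound 3 `COc1ccccc1N1CCN(CCC(Oc2ccc(C(=O)Nc3ccccc3OCCCC(=O)O)cc2)c2ccc(CC(C)C)cc2)CC1` is not yet measured. Relative to compound 2 the change is isopropyl in place of methyl on a saturated chain carbon bound to an aromatic carbon. Among the measured compounds shown here, the one step that bears on it is a 2.5-fold higher number from compound 1 to compound 2 (0.40 log units; beyond the scatter), which runs in the same direction, a longer chain at the same place. For the measured compounds named here, with only this single step the pattern rests on two compounds, but it points toward weaker binding as the chain grows.

Compound 3 is therefore expected to give a step of a 2.0-fold higher number from compound 2 to compound 3 (0.30 log units; within the scatter), a further rise in the number, though the size is uncertain with one reference step. The estimate for compound 3 in this assay is 80 nM, with a range from 30 nM to 250 nM.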

Compound 3, dissociation constant: 2000 nM
The estimate for compound 3 lay 25-fold (1.40 log units) below the measured number; measured number above the stated range.
By their numbers in this assay, from the lowest: compound 1; then compound 2; then compound 3.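

In this assay, going from 4-ethylphenyl to 4-isobutylphenyl gives a 50-fold higher number from compound 2 to compound 3 (1.70 log units; beyond the scatter), against only a 2.5-fold higher number from compound 1 to compound 2 (0.40 log units; beyond the scatter) for the preceding change at the same place, so the response at this position to growth of the alkyl group is not an even slope but a sharp drop in binding at the last change. Over the whole run there is a 130-fold higher number from compound 1 to compound 3 (2.10 log units; beyond the scatter), and the numbers rise in the same order as the group grows, with none of the three compounds going against that order, although three compounds make only a short series. No measurement at hand accounts for the size of this jump.

The compounds shown do not separate branching from the added carbons alone: an unbranched propyl or butyl chain at this place would tell these apart, as would a cyclopropyl group of similar carbon count. Also open, as far as these compounds go, is the lower end of the series, since the aromatic ring with a hydrogen in place of the alkyl group does not appear here, nor does any oxygen-bearing group such as methoxy.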